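The source may report more compounds than this note shows. Statements on the series, on what has been measured and on what is new or still open speak of the compounds shown alone.

Measured so far:
compound 1, `O=C(Nc1cccc(-n2cc(-c3ccncc3)c(-c3ccc(Cl)c(O)c3)n2)c1)Nc1ccc(Cl)c(Cl)c1`: 930 nM
compound 2, `COc1cc(-c2nn(-c3cccc(NC(=O)Nc4cccc(C(F)(F)F)c4)c3)cc2-c2ccncc2)ccc1Cl`: 923 nM

Of the compounds shown here, two have been measured in a functional assay on UACC-257 cells (Homo sapiens) for inhibition, read by sulforhodamine B assay, with a stated time of 48 h; a lower number here means a stronger inhibitor of growth, a higher number a weaker inhibitor of growth. Compound 1, `O=C(Nc1cccc(-n2cc(-c3ccncc3)c(-c3ccc(Cl)c(O)c3)n2)c1)Nc1ccc(Cl)c(Cl)c1`, gives 930 nM in this assay. Compound 2, `COc1cc(-c2nn(-c3cccc(NC(=O)Nc4cccc(C(F)(F)F)c4)c3)cc2-c2ccncc2)ccc1Cl`, gives 923 nM. The two numbers sit on top of each other, well inside the scatter of repeated measurements, so neither compound can be set apart from the other on this evidence; compound 1 simply shares the only level that has been seen so far.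

The next compound, compound 3, `O=C(Nc1cccc(-n2cc(-c3ccncc3)c(-c3ccc(Cl)c(O)c3)n2)c1)Nc1ccc(Cl)c(C(F)(F)F)c1`, keeps the core of compound 1 and changes one group on the outer phenyl of the urea: trifluoromethyl in place of chloro on an aromatic carbon. Within the data shown here, no step of this kind has been measured here, so there is no directly comparable pair to lean on. Among the measured compounds shown here, the one hint comes from compound 2, which also carries a trifluoromethyl on that ring and lands at the same level as compound 1. A step of about the size of the scatter, in either direction or none at all, is therefore what is expected; the estimate for compound 3 is 800 nM, with a range from 300 nM to 2500 nM, which corresponds to an expected step of a 1.2-fold lower number from compound 1 to compound 3 (0.07 log units; within the scatter).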

Compound 3, concentration for 50% growth inhibition: 768 nM
Beside the measured number, compound 3's estimate is 1.0-fold (0.02 log units) above it; the range from low to high includes it.
By their numbers in this assay, from the lowest: compounds 3, 2 and 1 (each within the scatter of the next).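

In this assay, trifluoromethyl in place of chloro on this aromatic carbon, ortho to a chloro group and meta to a large group, gives a 1.2-fold lower number from compound 1 to compound 3 (0.08 log units; within the scatter), a step that stays within the scatter. Among these compounds, this is the first direct reading at this position: compound 2 also carries a trifluoromethyl on that ring but differs from compound 1 in more than one place, whereas here the 3,4-dichlorophenyl and the 4-chloro-3-(trifluoromethyl)phenyl on the urea can be set side by side with the rest of the molecule unchanged, and the two cannot be told apart in this assay. Nothing measured here bears on what lies behind this result.

The compounds shown leave open whether this position would stay at the same level with a group of another kind, such as a nitrile, an amine or a carboxylic acid, since only chloro and trifluoromethyl have been seen on this carbon in the shared core. They also leave open what happens when the chloro group on the same ring is replaced while this position is held constant.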